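A few compounds are considered here, and "the series" means these few. Any claim that something is new, unique, unknown or untested is made for them only; others in the source may bear on it.

Series notes. The shared core is that of compound 1 `COc1cc2c(Oc3ccc(NC(=O)c4cn(-c5ccccc5)nn4)cc3F)ccnc2cc1OCCCN1CCCC1`, which in a functional assay on NCI-H460 cells (Homo sapiens) for cytotoxicity, read by MTT assay, with a stated time of 72 h (on this read-out higher numbers stand for weaker inhibition and lower numbers for stronger inhibition), gives 280 nM. Compound 3 `COc1cc2c(Oc3ccc(NC(=O)c4cn(-c5ccc(Br)cc5)nn4)cc3F)ccnc2cc1OCCCN1CCCC1` gives 200 nM in this assay, and compound 2 `COc1cc2c(Oc3ccc(NC(=O)c4cn(-c5ccccc5C)nn4)cc3F)ccnc2cc1OCCCN1CCCC1` gives 1260 nM in this assay, the highest number of the three: a 4.5-fold higher number from compound 1 to compound 2 (0.65 log units; beyond the scatter) and a 6.3-fold lower number from compound 2 to compound 3 (0.80 log units; beyond the scatter), both beyond the scatter, whereas a 1.4-fold lower number from compound 1 to compound 3 (0.15 log units; within the scatter). Compound 4 `COc1cc2c(Oc3ccc(NC(=O)c4cn(-c5c(C)cccc5C)nn4)cc3F)ccnc2cc1OCCCN1CCCC1` differs from compound 2 by methyl in place of hydrogen on an aromatic carbon. Among the measured compounds shown here, only one measured step bears on it, the same change made once, and it went the wrong way. For compound 4 a further rise is expected because a 4.5-fold higher number from compound 1 to compound 2 (0.65 log units; beyond the scatter), so the estimated step is a 2.2-fold higher number from compound 2 to compound 4 (0.35 log units; beyond the scatter) in this assay. Compound 4 is therefore estimated at 2800 nM in this assay, with a range of 900 nM to 9000 nM.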

Compound 4, half-maximal inhibitory concentration: 1560 nM
Compound 4: the middle estimate sits 1.8-fold (0.25 log units) above what was measured; low and high end bracket the measured number.
By their numbers in this assay, from the lowest: compounds 3 and 1 (each within the scatter of the next); then compounds 2 and 4 (each within the scatter of the next).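

In this assay, the change from 2-methylphenyl to 2,6-dimethylphenyl is a 1.2-fold higher number from compound 2 to compound 4 (0.09 log units; within the scatter), so the methyl swap that counted on the phenyl ring of compound 1 does not count a second time. The 2,6-dimethylphenyl group remains apart from the plain phenyl, a 5.6-fold higher number from compound 1 to compound 4 (0.75 log units; beyond the scatter), and from 4-bromophenyl, a 7.8-fold higher number from compound 3 to compound 4 (0.89 log units; beyond the scatter). Compounds 2 and 4 therefore stand together, apart from compounds 1 and 3.

Nothing measured accounts for this pattern. As far as these compounds go, whether it is specific to methyl stays open, as a chlorine, methoxy group or amine on that same aromatic carbon could read differently.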